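The compounds below may be only part of what the source reports. "The series", "measured", "known", "first", "only" and "open" are said of these compounds alone.

Of the compounds shown here, two of one family have so far been measured in a functional assay on HeLa cells (Homo sapiens) for antiproliferative activity, read by CCK-8 assay, with a stated time of 72 h, tested at 8 uM; a higher number here means a stronger effect of the compound at the concentration tested, a lower number a weaker effect. Compound 1, `Nc1ccccc1NC(=O)c1ccc(CSC(=S)N2CCN(c3ccc(Cl)cc3)CC2)cc1`, gives 44.8% in this assay. Compound 2, `CN(C(=S)SCc1ccc(C(=O)Nc2ccccc2N)cc1)c1cccnc1`, gives 70.5% in this assay. Compound 1 thus stands lowest of the two numbers, and its nearest neighbour, compound 2, lies higher by a margin beyond the usual scatter of repeated measurements. The two differ in more than one place, so what drives this gap cannot be read from the pair.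

Compound 3, `Nc1ccccc1NC(=O)c1ccc(CSC(=S)N2CCN(c3ccc(F)cc3)CC2)cc1`, has not yet been measured in this assay. It differs from compound 1 in one place: fluoro in place of chloro on an aromatic carbon. Going by the values given here, no pair of measured compounds shows this exact change, so there is no measured step to lean on. With only that to go on, the expected step is a number 0.2 percentage points higher from compound 1 to compound 3 (within the scatter), not beyond the usual scatter in either direction. Compound 3 is therefore estimated to give about 45% in this assay, within a range from 30% to 60%.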

Compound 3, a percentage reported as inhibition, at one concentration (the size of the read-out at that concentration, not a potency): 64.5%
Compound 3: the middle estimate sits 19.5 percentage points below what was measured; measured number outside the range, above it.
By their numbers in this assay, from the lowest: compound 1; then compounds 3 and 2 (each within the scatter of the next).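

In this assay, the change from 4-chlorophenyl to 4-fluorophenyl gives a number 19.7 percentage points higher from compound 1 to compound 3 (beyond the scatter). This position, on an aromatic carbon para to a large group, is therefore not indifferent to which halogen it carries: exchanging one heavy atom for another shifts the read-out, even though no ring, hydrogen-bond donor, hydrogen-bond acceptor or net charge enters or leaves. Nothing available here bears on the reason for this step.

With only chloro and fluoro shown at this position, a single step cannot say how the read-out would respond to a hydrogen, a bromo, a methoxy group or an amine there, or whether fluoro is a favourable choice among such groups or merely better than chloro. It also leaves open whether the same exchange would have a similar effect on a different core, or at other concentrations, since this read-out reports the size of the effect at one concentration and is not a measure of potency.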